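The source may hold more compounds than are shown below. What is called first, only, known or untested is meant among the compounds shown, and "the series" means these compounds.

Compound 1 `COc1cccc(CNC(=O)c2nc(Br)c3cccnc3c2N[C@H]2CC[C@H](N)CC2)c1` gives 6000 nM in a functional assay on HCT-116 cells (Homo sapiens) for cytotoxicity, read by MTT assay, with a stated time of 72 h; a higher number here means a weaker inhibitor, a lower number a stronger inhibitor. Of the two numbers measured in this series it is the lower; compound 3 `CNCCCNc1c(C(=O)NCc2ccc(F)cc2)nc(Br)c2cccnc12` gives 9000 nM in this assay, and the two values lie within the scatter of each other. For the measured compounds named here, compound 2 `NCCNc1c(C(=O)NCc2ccc(F)cc2)nc(Br)c2cccnc12` reaches only a limit of this assay, > 20000 nM, and is the one value sitting at the limit of > 20000 nM in this assay, at which 1 of the 3 values shown sits. Going by the values given here, the single measured step, an at least 2.2-fold lower number from compound 2 to compound 3 (0.34 log units; beyond the scatter), concerns the chain carried by the nitrogen on the aromatic ring and not the amide side of the core.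

Compound 4 `N[C@H]1CC[C@H](Nc2c(C(=O)NCc3ccc(F)cc3)nc(Br)c3cccnc23)CC1` differs from compound 1 in the amide side alone: 4-fluorophenyl in place of 3-methoxyphenyl on a saturated chain carbon bound to an amide-type nitrogen. Among the compounds with values here, no measured step touches this part of the core, so nothing among the measured compounds sets a direction for it. Compound 3 already carries the 4-fluorobenzyl amide with a different amine and gives a number within the scatter of compound 1. For compound 4 a step of a 1.2-fold higher number from compound 1 to compound 4 (0.07 log units; within the scatter) is therefore expected, not beyond the scatter. Compound 4 is estimated at 7000 nM in this assay, with a range from 3000 nM to 16000 nM.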

Compound 4, half-maximal inhibitory concentration: 7000 nM
Beside the measured number, compound 4's estimate shows no gap at the digits printed; measured number inside the range.
By their numbers in this assay, from the lowest: compounds 1, 4 and 3 (each within the scatter of the next). At a limit, above all of these: compound 2.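

On the amide side, 4-fluorophenyl in place of 3-methoxyphenyl on a saturated chain carbon bound to an amide-type nitrogen gives a 1.2-fold higher number from compound 1 to compound 4 (0.07 log units; within the scatter) in this assay, so this one exchange at this position stays within the scatter. On the nitrogen on an aromatic ring, with the 4-fluorobenzyl amide held, 4-aminocyclohexyl in place of 3-(methylamino)propyl gives a 1.3-fold lower number from compound 3 to compound 4 (0.11 log units; within the scatter), whereas 4-aminocyclohexyl in place of 2-aminoethyl gives an at least 2.8-fold lower number from compound 2 to compound 4 (0.45 log units; beyond the scatter). That last step is read against a limit and not a number, and the limit is that of compound 2: the limit of > 20000 nM in this assay, at which 1 of the 4 values shown sits.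

From the compounds shown here alone, whether the amide position tolerates a larger change, such as a 2-phenylethyl group or a pyridinylmethyl group, remains open. Also open, going by these compounds, is what a carboxylic acid or a dimethylamino group would do in place of the amino group of 4-aminocyclohexyl.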